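The compounds below may be only part of what the source reports. "The series", "measured", "known", "first", "only" and "open" are said of these compounds alone.

Three compounds have been measured in a functional assay on brain (Rattus norvegicus, strain Wistar) for inhibition; on this read-out lower numbers stand for stronger inhibition and higher numbers for weaker inhibition:

Compound 1 `Cc1[nH]c(=O)n(C)c1-c1ccc(CC(C)C)cc1` gives 7800 nM
Compound 2 `CCCCCc1ccc(-c2c(C)[nH]c(=O)n2C)cc1` gives 5900 nM
Compound 3 `CCCCCCCc1ccc(-c2c(C)[nH]c(=O)n2C)cc1` gives 8400 nM

Compound 3 stands level with the other two, as its value lies within the scatter of both. This is shown by a 1.1-fold higher number from compound 1 to compound 3 (0.03 log units; within the scatter) and by a 1.4-fold higher number from compound 2 to compound 3 (0.15 log units; within the scatter).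

The next compound is compound 4 `Cc1[nH]c(=O)n(C)c1-c1ccc(Oc2ccccc2)cc1`, which has phenoxy in place of heptyl on an aromatic carbon.

The measured steps that bear on this change all concern the saturated chain. Besides the two steps to compound 3, there is a 1.3-fold lower number from compound 1 to compound 2 (0.12 log units; within the scatter). None of these steps goes beyond the scatter, so this assay has so far shown no response to the changes made at this place. For the measured compounds named here, they are only a partial guide, however, since none of the measured compounds carries a ring at this position, and the data do not show what such a ring does. The expectation is therefore no step beyond the scatter, with no favoured direction, though with generous uncertainty.

The estimated change is a 1.4-fold lower number from compound 3 to compound 4 (0.15 log units; within the scatter). For compound 4 the expected value is 6000 nM, with an estimated range from 1500 nM to 20000 nM.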

Compound 4, half-maximal inhibitory concentration: 8100 nM
The estimate for compound 4 lay 1.4-fold (0.13 log units) below the measured number, within the range that was stated.
By their numbers in this assay, from the lowest: compounds 2, 1, 4 and 3 (each within the scatter of the next).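

In this assay, for the compounds shown here, phenoxy, the only ring among the groups at this place, stands level with all three saturated chains: there is a 1.0-fold lower number from compound 3 to compound 4 (0.02 log units; within the scatter) against heptyl, a 1.4-fold higher number from compound 2 to compound 4 (0.14 log units; within the scatter) against pentyl and a 1.0-fold higher number from compound 1 to compound 4 (0.02 log units; within the scatter) against isobutyl. The flat response is therefore no longer confined to changes in a saturated chain, since replacing the chain with a six-membered aromatic ring of carbon only, attached through an oxygen that adds a hydrogen-bond acceptor, also produces no step beyond the scatter. All four compounds now lie within the scatter of one another, and no supporting information is available to explain this insensitivity.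

The compounds shown leave open whether any group on this aromatic carbon can move the number beyond the scatter, for example an amine or a carboxylic acid in place of phenoxy, or a fluorine on the phenoxy ring. They also leave open whether changes elsewhere would do so, as all four compounds share the same core and differ only at this one place.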